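The source may hold more compounds than are shown below. What is called first, only, known or untested is meant among the compounds shown, and "the series" means these compounds.

Series notes. Compound 1 `COc1cc(OC)c(C(=O)/C=C/c2ccc([N+](=O)[O-])cc2)c(OC)c1` serves as the reference; in a functional assay for inhibition, with Homo sapiens as the target (on this read-out higher numbers stand for weaker inhibition and lower numbers for stronger inhibition), compound 1 gives 407 nM. Compound 2 `COC(=O)c1ccc(/C=C/C(=O)c2c(OC)cc(OC)cc2OC)cc1` carries the change (methoxycarbonyl in place of nitro on an aromatic carbon); in this assay compound 2 gives 1930 nM, and the step is a 4.7-fold higher number from compound 1 to compound 2 (0.68 log units; beyond the scatter). Compound 3 `O=C(/C=C/c1ccccc1)c1ccccc1[N+](=O)[O-]` belongs to a second core, and the difference between the two cores is not broken down here. In this assay compound 3 gives 1520 nM, which lies close to compound 2 and well apart from compound 1.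

Compound 4 `COC(=O)c1ccccc1C(=O)/C=C/c1ccccc1` has not yet been measured. It differs from compound 3 by methoxycarbonyl in place of nitro on an aromatic carbon, the same kind of change as that between compound 1 and compound 2, which is the only measured instance of it; the change occurs twice among the compounds shown. The place is not identical: in compound 1 the nitro stands para to a large group, whereas in compound 3 it stands ortho to a large group, so the earlier step is a guide rather than a copy.

Compound 4 is expected to give a higher number than compound 3 because the step of a 4.7-fold higher number from compound 1 to compound 2 (0.68 log units; beyond the scatter) ran toward weaker inhibition. With one measured instance and a differently placed group, the expected step of a 3.3-fold higher number from compound 3 to compound 4 (0.52 log units; beyond the scatter) is kept somewhat smaller than that earlier one. Compound 4 is estimated at 5000 nM in this assay. The expected range for compound 4 runs from 1500 nM to 15000 nM.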

Compound 4, half-maximal inhibitory concentration: 1950 nM
For compound 4 the middle estimate is 2.6-fold (0.41 log units) above the measured one; low and high end bracket the measured number.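

In this assay, methoxycarbonyl in place of nitro on an aromatic carbon gives a 1.3-fold higher number from compound 3 to compound 4 (0.11 log units; within the scatter), so the step seen on the core of compound 1 does not carry over in size to the core of compound 3: the same change on two cores in this assay, a 4.7-fold higher number (0.68 log units; beyond the scatter) from compound 1 to compound 2 and a 1.3-fold higher number (0.11 log units; within the scatter) from compound 3 to compound 4, 3.7-fold (0.57 log units) apart, beyond the scatter of two such steps A step measured on one core is therefore a poor guide to its size on the other, and the direction seen on the core of compound 1 cannot be confirmed on the core of compound 3, where the step stays within the scatter. This does not show what sets the two steps apart, since the pairs differ in core and also in the place of the change, which in compound 3 and compound 4 lies ortho to a large group, and two pairs give no general rule for the series.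

The compounds shown leave open whether the difference follows the core or the place, as neither core carries the change in both places. They also leave open how other groups behave at this place on the core of compound 3, such as a carboxylic acid, an amide or a nitrile, and whether any of them would separate from nitro beyond the scatter.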